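A few compounds are considered here, and "the series" means these few. Any claim that something is new, unique, unknown or untested is made for them only; others in the source may bear on it.

Compound 1 `O=C(/C=C/c1ccc(O)cc1)c1c(O)cccc1OCC1CCCCC1` carries a cyclohexyl group on the chain attached through oxygen to its core. In a functional assay on MDA-MB-231 cells (Homo sapiens) for antiproliferative activity, read by sulforhodamine B assay (a higher number here means a weaker inhibitor of growth, a lower number a stronger inhibitor of growth), compound 1 gives > 30000 nM, which is a limit of the assay rather than a measured number. Compound 2 `CC(C)CCCOc1cccc(O)c1C(=O)/C=C/c1ccc(O)cc1` gives 3480 nM, and compound 3 `CC(C)(C)CCOc1cccc(O)c1C(=O)/C=C/c1ccc(O)cc1` gives 2380 nM. Compound 4 `CC(C)CCOc1cccc(O)c1C(=O)/C=C/c1ccc(O)cc1` differs from compound 1 in one place: isobutyl in place of cyclohexyl on a saturated chain carbon bound to an oxygen on an aromatic ring. Going by the values given here, two measured steps bear on this change: an at least 8.6-fold lower number from compound 1 to compound 2 (0.93 log units; beyond the scatter) and an at least 12-fold lower number from compound 1 to compound 3 (1.10 log units; beyond the scatter). Both exchange the cyclohexyl for an open branched chain, and both lower the number well beyond the scatter; between the two open chains themselves a 1.5-fold lower number from compound 2 to compound 3 (0.17 log units; within the scatter). Isobutyl is another open branched chain, so a drop of comparable size is expected here. Compound 4 is therefore estimated at 4000 nM, between 1500 nM and 15000 nM, the expected step being an at least 7.5-fold lower number from compound 1 to compound 4 (0.87 log units; beyond the scatter).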

Compound 4, concentration for 50% growth inhibition: 10300 nM
Compound 4: middle estimate off by 2.6-fold (0.41 log units), on the low side; measured number inside the range.
By their numbers in this assay, from the lowest: compounds 3 and 2 (each within the scatter of the next); then compound 4. At a limit, above all of these: compound 1.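

Putting isobutyl in place of cyclohexyl gives an at least 2.9-fold lower number from compound 1 to compound 4 (0.46 log units; beyond the scatter), so removing the ring is enough to lower the number beyond the scatter. Open chains are not all alike, though: small changes further out along the chain give a 4.3-fold higher number from compound 3 to compound 4 (0.64 log units; beyond the scatter) and a 3.0-fold higher number from compound 2 to compound 4 (0.47 log units; beyond the scatter). Compound 1 stands at a limit, so the full size of its step stays unknown: the limit of > 30000 nM in this assay, at which 1 of the 4 values shown sits.

On these data alone, what a chain ending in an amine or a carboxylic acid would do remains open. So does the effect of a smaller ring, such as cyclopentyl, in place of cyclohexyl.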